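From 4-methoxyphenyl to 3,4,5-trimethoxyphenyl on the shared core

The source may report more compounds than this note shows. Statements on the series, on what has been measured and on what is new or still open speak of the compounds shown alone.

In a functional assay on HepG2 cells (Homo sapiens) for inhibition, read by MTT assay, with a stated time of 48 h (on this read-out higher numbers stand for weaker inhibition of growth and lower numbers for stronger inhibition of growth), compound 1 `Cn1cc(C2CC(c3ccc(F)cc3)=NN2C(=O)c2cccnc2)c2cc(Br)ccc21` gives 480 nM and compound 2 `COc1ccc(C2=NN(C(=O)c3cccnc3)C(c3cn(C)c4ccc(Br)cc34)C2)cc1` gives 540 nM. For the measured compounds named here, compound 2 therefore stands level with compound 1, the only other measured member of the series, and the two cannot be told apart. Going by the values given here, the single measured step, a 1.1-fold higher number from compound 1 to compound 2 (0.05 log units; within the scatter), is methoxy in place of fluoro on an aromatic carbon and lies within the scatter.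

Compound 3 `COc1cc(C2=NN(C(=O)c3cccnc3)C(c3cn(C)c4ccc(Br)cc34)C2)cc(OC)c1OC` has not yet been measured in this assay. The change is 3,4,5-trimethoxyphenyl in place of 4-methoxyphenyl on a carbon with a double bond to nitrogen. Among the compounds with values here, the measured step touches the same aromatic ring and is the only guide available. Within the data shown here, no measured compound carries the 3,4,5-trimethoxyphenyl group, so the guide is thin and the range must stay wide. Given the small size of a 1.1-fold higher number from compound 1 to compound 2 (0.05 log units; within the scatter), no step beyond the scatter is expected, in either direction. The expected step is a 1.2-fold lower number from compound 2 to compound 3 (0.08 log units; within the scatter). In this assay the estimate for compound 3 is 450 nM, with an expected range of 150 nM to 1350 nM.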

Compound 3, concentration for 50% growth inhibition: > 10000 nM
Compound 3 ended at the assay's limit; the forecaster's own chance of this, stated with the estimate: 3%; middle value at least 22-fold (1.34 log units) away from the limit.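

In this assay compound 3 gives > 10000 nM, which is a limit of the assay and not a number: the limit of > 10000 nM in this assay, at which 1 of the 3 values shown sits.

The exchange on the carbon with a double bond to nitrogen gives an at least 18-fold higher number from compound 2 to compound 3 (1.26 log units; beyond the scatter), and the comparison with the 4-fluorophenyl compound gives an at least 20-fold higher number from compound 1 to compound 3 (1.31 log units; beyond the scatter). Compound 1 and compound 2 could not be told apart, so on their own they suggested a position indifferent to the aryl group it carries, whereas compound 3 shows that this position does not accept every aryl group and that 3,4,5-trimethoxyphenyl here goes with much weaker inhibition of growth.

On these data alone, whether the added methoxy groups produce this step singly or only together stays open, and the true size of the step is unknown beyond what the limit allows. Also open, as far as these compounds go, is how an unsubstituted phenyl, or a phenyl carrying an amine or a carboxylic acid, would stand at this position on the shared core.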